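The source may hold more compounds than are shown below. What is called first, only, known or untested is meant among the compounds shown, and "the series" means these compounds.

Measured compounds:
- Compound 1, `COc1cc2c(cc1C(C)NCCCc1ccccc1)C=CC(C)(C)O2`: 11 nM
- Compound 2, `COc1ccc(CNC(C)c2cc3c(cc2OC)OC(C)(C)C=C3)cc1`: 165 nM
- Compound 3, `COc1cc2c(cc1C(C)NCc1ccccc1)CCC(C)(C)O2`: 119 nM

All three values come from an assay on cell membranes for displacement of a labelled ligand from Sigma non-opioid intracellular receptor 1 (Cavia porcellus), read by scintillation counting; a higher number here means a weaker inhibitor, a lower number a stronger inhibitor. Among them compound 3 stands second highest; its number sits close to that of compound 2, a gap within the usual scatter, while compound 1 gives a number far lower than compound 3, a gap beyond the scatter. Compound 4, `COc1cc2c(cc1C(C)NCCCc1ccccc1)CCC(C)(C)O2`, has not yet been measured. It differs from compound 3 in one place: phenethyl in place of phenyl on a saturated chain carbon bound to an amine nitrogen.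

Within the data shown here, one measured step bears on this change. The step of a 15-fold higher number from compound 1 to compound 2 (1.18 log units; beyond the scatter) shows that exchanging phenethyl for an aryl group on the same kind of chain carbon cost a large amount in this assay. The change from compound 3 to compound 4 runs the other way, from an aryl group back to phenethyl, so the expectation is a drop in the number of a similar size. The comparison of compound 1 with compound 3 involves two differences at once, so it adds only loose support: compound 1 carries phenethyl and gives the lowest number of the three.

For compound 4 the estimated step is a 9.9-fold lower number from compound 3 to compound 4 (1.00 log units; beyond the scatter), and the expected value in this assay is 12 nM, with a likely range from 4 nM to 40 nM.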

Compound 4, inhibition constant: 19 nM
Compound 4: middle estimate off by 1.6-fold (0.20 log units), on the low side, within the range that was stated.
By their numbers in this assay, from the lowest: compounds 1 and 4 (each within the scatter of the next); then compounds 3 and 2 (each within the scatter of the next).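

In this assay, the step of a 6.3-fold lower number from compound 3 to compound 4 (0.80 log units; beyond the scatter) shows that phenethyl on a saturated chain carbon bound to an amine nitrogen also gives the lower number on the core of compound 3, and against plain phenyl; the earlier step had shown this only on the core of compound 1, against 4-methoxyphenyl. With phenethyl in place, compound 1 at 11 nM and compound 4 at 19 nM lie within the scatter of each other, so these values do not separate the two cores. No measured evidence here accounts for the gain.

As far as these compounds go, whether the number changes further with a longer chain, such as 4-phenylbutyl, or with a chain carrying no ring, such as hexyl, remains open. How phenyl and 4-methoxyphenyl compare on a single core is also unresolved.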